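Hydrazone aryl swap on a weakly active series

This account rests on a few compounds, and the source may have more. Where it says the series, first, only, none or still open, it means among the compounds named here.

Among the compounds with values here, compound 1 `C#CCSc1nc(N/N=C/c2ccc(N(C)C)cc2)c2nnn(Cc3ccccc3)c2n1` is the only member of this small set that yields a number: in a functional assay on ECa-109 cells (Homo sapiens) for antiproliferative activity, read by MTT assay, with a stated time of 72 h (on this read-out higher numbers stand for weaker inhibition and lower numbers for stronger inhibition), compound 1 gives 31300 nM. Compound 2 `CCCSc1nc(N/N=C/c2ccc(Cl)cc2)c2nnn(Cc3ccccc3)c2n1` reaches only a limit of the assay, > 64000 nM. Compound 3 `CCCSc1nc(N/N=C(\C)c2ccc(OC)cc2)c2nnn(Cc3ccccc3)c2n1` likewise stops at a limit, > 64000 nM. Within the data shown here, two of the three results therefore sit at the limit of > 64000 nM in this assay, at which 2 of the 3 values shown sit, leaving compound 1 as the sole anchor for comparison, and since the three measured compounds differ from one another in more than one place, no single step between measured compounds can be sized.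

Compound 4 `C#CCSc1nc(N/N=C/c2c(O)ccc3ccccc23)c2nnn(Cc3ccccc3)c2n1` departs from compound 1 at one point: 2-hydroxynaphthalen-1-yl in place of 4-(dimethylamino)phenyl on a carbon with a double bond to nitrogen. The measured set contains no isolated change of this kind, so the size of the step must be estimated without a precedent.

The expected step of a 2.1-fold lower number from compound 1 to compound 4 (0.32 log units; beyond the scatter) is towards stronger inhibition, but only a little beyond the usual scatter of such measurements. For compound 4 the estimate in this assay is 15000 nM, with a range from 4000 nM to 64000 nM, and a real chance that the assay again returns only a limit.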

Compound 4, half-maximal inhibitory concentration: 6520 nM
Beside the measured number, compound 4's estimate is 2.3-fold (0.36 log units) above it; the measured number falls inside the stated range.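

Within the data shown here, this is the first single change in this assay whose size can be read: 2-hydroxynaphthalen-1-yl in place of 4-(dimethylamino)phenyl on a carbon with a double bond to nitrogen gives a 4.8-fold lower number from compound 1 to compound 4 (0.68 log units; beyond the scatter), so the group at this position does shift the read-out, though only modestly and on a weakly active series. The change swaps one six-membered aromatic ring of carbon only for two and brings in a hydrogen-bond donor, and nothing measured here accounts for the gain. Steps involving compound 2 and compound 3 cannot be read, as they differ from the others in more than one place and their results are limits of the assay: the limit of > 64000 nM in this assay, at which 2 of the 4 values shown sit.

The compounds shown leave open whether the second aromatic ring or the hydroxyl carries the step, a question that a naphthyl group with no hydroxyl or a hydroxyphenyl group at the same place would address. They also leave open whether the same swap would have a similar effect on a core that carries a propyl chain on sulfur.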